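Swapping a Nitro Substituent for Methoxy on the Shared Core

This account rests on a few compounds, and the source may have more. Where it says the series, first, only, none or still open, it means among the compounds named here.

Of the compounds shown here, two have so far been measured in a functional assay on PC-3 cells (Homo sapiens) for cytotoxicity, read by sulforhodamine B assay, with a stated time of 48 h; on this read-out higher numbers stand for weaker inhibition and lower numbers for stronger inhibition. Compound 1 `CC(=O)N1N=C(c2cccc([N+](=O)[O-])c2)CC1c1ccccc1` gives 8710 nM in this assay. Compound 2 `CC(=O)N1N=C(c2cccc3ccccc23)CC1c1ccccc1[N+](=O)[O-]` gives 3540 nM in this assay, the lower of the two numbers, and its gap to compound 1 lies beyond the usual scatter, so compound 2 stands as the stronger of the measured pair.

Compound 3 `COc1ccc(C2CC(c3cccc4ccccc34)=NN2C(C)=O)cc1` keeps the core of compound 2 and alters one group: 4-methoxyphenyl in place of 2-nitrophenyl on a saturated ring carbon. Among the compounds with values here, no measured pair isolates this exchange, and compounds 1 and 2 differ from each other in more than one place, so their values give no direct guide to it. With nothing to anchor the direction, a small step is expected in this assay, leaning toward a somewhat higher number but quite possibly staying within the scatter. The step expected here is a 1.4-fold higher number from compound 2 to compound 3 (0.15 log units; within the scatter). Compound 3 is therefore estimated at about 5000 nM in this assay, with a plausible range from 1500 nM to 20000 nM.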

Compound 3, half-maximal inhibitory concentration: 4930 nM
Compound 3: the middle estimate sits 1.0-fold (0.01 log units) above what was measured; low and high end bracket the measured number.
By their numbers in this assay, from the lowest: compounds 2, 3 and 1 (each within the scatter of the next, the first and the last beyond it).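

Within the data shown here, this is the first pair in this assay that differs in one place only, and the exchange of 2-nitrophenyl for 4-methoxyphenyl on a saturated ring carbon gives a 1.4-fold higher number from compound 2 to compound 3 (0.14 log units; within the scatter) with the rest of the shared core held fixed. That step lies within the scatter, so the two compounds cannot be told apart here, and this position accepts either group without a readable effect on the number, even though one group carries nitrogen and oxygen and the other carries oxygen alone. No other measurement bears on this result, so it offers no explanation of why the numbers match.

On these data alone, the exchange alters the substituent and its numbered place on the phenyl ring together, so it remains open whether 4-nitrophenyl or 2-methoxyphenyl would read the same. The compounds shown also leave open how far this acceptance extends, for example to an amine or a carboxylic acid on the phenyl ring in place of the methoxy group.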